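The source may report more compounds than this note shows. Statements on the series, on what has been measured and on what is new or still open speak of the compounds shown alone.

Three compounds share one core, a coumarin-bearing enaminone joined to a benzenesulfonamide, and differ only in the heteroaryl group on the sulfonamide nitrogen. Compound 1 `Cc1noc(NS(=O)(=O)c2ccc(N/C=C\C(=O)c3cc4ccccc4oc3=O)cc2)c1C` gives 68400 nM in a functional assay on T47D cells (Homo sapiens) for cytotoxicity, read by sulforhodamine B assay, with a stated time of 48 h; a lower number here means a stronger inhibitor, a higher number a weaker inhibitor. Compound 2 `Cc1nnc(NS(=O)(=O)c2ccc(N/C=C\C(=O)c3cc4ccccc4oc3=O)cc2)s1` gives 94000 nM in this assay, and compound 3 `O=C(/C=C\Nc1ccc(S(=O)(=O)Nc2ncccn2)cc1)c1cc2ccccc2oc1=O` gives 75200 nM. Among these three numbers compound 3 stands second highest, with compound 1 nearest and compound 2 furthest. The steps are all small: a 1.4-fold higher number from compound 1 to compound 2 (0.14 log units; within the scatter), a 1.1-fold higher number from compound 1 to compound 3 (0.04 log units; within the scatter) and a 1.3-fold lower number from compound 2 to compound 3 (0.10 log units; within the scatter).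

Compound 4 `O=C(/C=C\Nc1ccc(S(=O)(=O)Nc2cnc3ccccc3n2)cc1)c1cc2ccccc2oc1=O` carries the change (quinoxalin-2-yl in place of pyrimidin-2-yl on a sulfonamide nitrogen). The three measured steps, each an exchange of the heteroaryl group on that same nitrogen, bear on this change, and none of them moved the number beyond the scatter. The expectation for this assay is therefore a step from compound 3 to compound 4 of no size beyond the scatter, a 1.0-fold lower number from compound 3 to compound 4 (0.00 log units; within the scatter). Compound 4 is accordingly estimated at 75000 nM, within a range from 30000 nM to 190000 nM.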

Compound 4, half-maximal inhibitory concentration: 86900 nM
The estimate for compound 4 lay 1.2-fold (0.06 log units) below the measured number; the range from low to high includes it.
By their numbers in this assay, from the lowest: compounds 1, 3, 4 and 2 (each within the scatter of the next).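

With quinoxalin-2-yl on the sulfonamide nitrogen, the group grows in heavy atoms from pyrimidin-2-yl and gains a six-membered aromatic ring of carbon only, yet the number in this assay stays within the scatter (a 1.2-fold higher number from compound 3 to compound 4 (0.06 log units; within the scatter)). The comparisons with the other two groups also stay within it (a 1.1-fold lower number from compound 2 to compound 4 (0.03 log units; within the scatter); a 1.3-fold higher number from compound 1 to compound 4 (0.10 log units; within the scatter)), so the added ring adds nothing that this assay can separate from the three earlier groups. No measurement offered here explains this insensitivity.

As far as these compounds go, all four groups on that nitrogen are aromatic, so it remains open whether an open-chain group such as ethyl or a saturated ring such as piperidin-4-yl would move the number. Equally open, from the compounds shown here alone, is whether a change elsewhere on the shared core would do so.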